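The source may hold more compounds than are shown below. What is called first, only, known or untested is meant among the compounds shown, and "the series" means these compounds.

In a functional assay on MDA-MB-435 cells (Homo sapiens) for cytotoxicity, read by MTT assay, with a stated time of 72 h (on this read-out higher numbers stand for weaker inhibition and lower numbers for stronger inhibition), compound 1 `O=C(NCc1ccc(F)cc1)c1nc(NCCO)c2cccnc2c1O` gives > 20000 nM as a limit of the assay and not as a number. Compound 2 `Nc1cccc(Nc2c(C(=O)NCc3ccc(F)cc3)nc(Br)c3cccnc23)c1` gives 8000 nM and compound 3 `N[C@H]1CC[C@H](Nc2c(C(=O)NCc3ccc(Oc4ccccc4)cc3)nc(Br)c3cccnc23)CC1` gives 4000 nM so these two values lie within the scatter of each other. Compound 2 therefore stands level with compound 3 on the numbers available. The change to compound 4 `CN(C)CCCNc1c(C(=O)NCc2ccc(F)cc2)nc(Br)c2cccnc12` reads 3-(dimethylamino)propyl in place of 3-aminophenyl on a nitrogen on an aromatic ring and puts 3-(dimethylamino)propyl in place of 3-aminophenyl on a nitrogen on an aromatic ring. Among the measured compounds shown here, no measured step covers this change. The expected step of a 1.6-fold lower number from compound 2 to compound 4 (0.20 log units; within the scatter) is a small one that does not go beyond the scatter in this assay when read. Compound 4 is estimated at 5000 nM with a range of 1500 nM to 16000 nM expected.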

Compound 4, half-maximal inhibitory concentration: 7000 nM
Compound 4: the middle estimate sits 1.4-fold (0.15 log units) below what was measured; low and high end bracket the measured number.
By their numbers in this assay, from the lowest: compounds 3, 4 and 2 (each within the scatter of the next). At a limit, above all of these: compound 1.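

In this assay, among the compounds shown here, replacing 3-aminophenyl with 3-(dimethylamino)propyl on a nitrogen on an aromatic ring gives a 1.1-fold lower number from compound 2 to compound 4 (0.06 log units; within the scatter), the first one-place comparison. In this pair, an open chain without a ring reads level with the aromatic group, so a ring at this position is not needed for a value at this level. Nothing measured here accounts for this result.

On these data alone, whether a longer chain, a primary amine at the chain end or a carboxylic acid would read differently at this position remains open.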